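A few compounds are considered here, and "the series" means these few. Any claim that something is new, unique, unknown or untested is made for them only; others in the source may bear on it.

Compound 1 `CCOc1ccccc1-c1cc(NC(=O)C(Cl)Cl)cc(-c2ccccc2OCC)c1`: 5090 nM
Compound 2 `O=C(Nc1cccc(-c2ccc(-c3ccccc3)cc2)c1)C(Cl)Cl`: 10900 nM
Compound 3 `CCOc1cccc(-c2cc(NC(=O)C(Cl)Cl)cc(-c3cccc(OCC)c3)c2)c1`: 4950 nM

All three were measured in a functional assay on NCI-H460 cells (Homo sapiens) for cytotoxicity, read by MTT assay, with a stated time of 68 h; a lower number here means a stronger inhibitor, a higher number a weaker inhibitor. Compound 2 has the highest number of the three, and its gaps to compound 1 and to compound 3 both lie beyond the scatter, which makes it the weakest so far. Compound 4 `COC(=O)c1ccc(-c2cccc(NC(=O)C(Cl)Cl)c2)cc1` has methoxycarbonyl in place of phenyl on an aromatic carbon, para to a large group (methoxycarbonyl in place of phenyl on an aromatic carbon). For the measured compounds named here, no measured pair shows this change, so compound 2, at 10900 nM, is the only guide. In this assay a small move toward a higher number is expected, not beyond the scatter. The expected step of a 1.3-fold higher number from compound 2 to compound 4 (0.11 log units; within the scatter) is only an estimate. For compound 4 the estimated value is 14000 nM, with an expected range of 6500 nM to 32000 nM.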

Compound 4, half-maximal inhibitory concentration: > 50000 nM
Compound 4 ended at the assay's limit; the forecaster's own chance of this, stated with the estimate: 10%; at least 3.5-fold (0.55 log units) between middle value and limit.
By their numbers in this assay, from the lowest: compounds 3 and 1 (each within the scatter of the next); then compound 2. At a limit, above all of these: compound 4.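

In this assay, for the compounds shown here, methoxycarbonyl in place of phenyl on an aromatic carbon, para to a large group, gives an at least 4.5-fold higher number from compound 2 to compound 4 (0.66 log units; beyond the scatter), the first single-place change. It shows that the group at this position matters for the read-out, at least for this pair. Compound 4 stands at a limit of the assay, so the step gives only a minimum and not a size: the limit of > 50000 nM in this assay, at which 1 of the 4 values shown sits. The compounds shown leave open whether the step comes from losing phenyl or from gaining methoxycarbonyl. They also leave open how a carboxylic acid, an amine or a methyl group at this position would read.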